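The compounds below may be only part of what the source reports. "The series", "measured", "known", "first", "only" and "open" are said of these compounds alone.

Measured so far in a functional assay on the whole organism (Tail, strain ICR) with Mus musculus as the target, in the tail flick test, with a stated time of 30 min, at a dose of 25 umol/kg by the oral route; a lower number here means a weaker effect, a higher number a stronger effect of the compound at the dose given:
Compound 1 `C[C@H](NC(=O)CN(c1ncnc2c1ncn2C1CCCCO1)C1CC1)C(=O)OCc1ccccc1` gives 55.9%.
Compound 2 `N=C(N)NCCC[C@H](NC(=O)CN(c1ncnc2c1ncn2C1CCCCO1)C1CC1)C(=O)OCc1ccccc1` gives 34.3%.
Compound 3 `CC(C)C[C@H](NC(=O)CN(c1ncnc2c1ncn2C1CCCCO1)C1CC1)C(=O)OCc1ccccc1` gives 26.2%.

Compound 3 stands lowest of the three numbers in this assay; its gap to compound 2 lies within the scatter, a number 8.1 percentage points lower from compound 2 to compound 3 (within the scatter), while its gap to compound 1 lies beyond it, a number 29.7 percentage points lower from compound 1 to compound 3 (beyond the scatter). Compound 4 `CC(C)[C@H](NC(=O)CN(c1ncnc2c1ncn2C1CCCCO1)C1CC1)C(=O)OCc1ccccc1` differs from compound 3 by isopropyl in place of isobutyl on a saturated chain carbon bound to an amide-type nitrogen and a carbonyl carbon. All measured steps concern the same saturated chain carbon, varied only in what stands on it: a number 21.6 percentage points lower from compound 1 to compound 2 (beyond the scatter) and a number 29.7 percentage points lower from compound 1 to compound 3 (beyond the scatter) both run downward when a larger group replaces hydrogen, and a number 8.1 percentage points lower from compound 2 to compound 3 (within the scatter) stays within the scatter. Compound 4 carries a group smaller than the isobutyl of compound 3 (26.2%) yet larger than the hydrogen of compound 1 (55.9%), so an activity between those two values is expected. The expected step is a number 11.8 percentage points higher from compound 3 to compound 4 (beyond the scatter), which may not clear the scatter. Compound 4 is therefore estimated at 38% in this assay, with a range of 22% to 54%.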

Compound 4, a percentage reported as activity, at one dose (the size of the read-out at that dose, not a potency): 21.8%
The estimate for compound 4 lay 16.2 percentage points above the measured number; the measured number lies below the stated range.
By their numbers in this assay, from the lowest: compounds 4, 3 and 2 (each within the scatter of the next, the first and the last beyond it); then compound 1.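

In this assay, isopropyl in place of isobutyl on the saturated chain carbon bound to an amide-type nitrogen and a carbonyl carbon gives a number 4.4 percentage points lower from compound 3 to compound 4 (within the scatter), so shortening this branched alkyl group does not recover the number of the methyl compound. Against that methyl group, isopropyl gives a number 34.1 percentage points lower from compound 1 to compound 4 (beyond the scatter), and against the group on this carbon in compound 2 it gives a number 12.5 percentage points lower from compound 2 to compound 4 (beyond the scatter); among the four compounds, compound 1 alone stands clear of the others at the top, while compound 2 stays within the scatter of compound 3. The data here offer nothing that accounts for these differences.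

Open, as far as these compounds go, is whether a hydrogen, an ethyl group or a straight propyl chain on this carbon would fall with methyl or with the branched groups. Also open, from the compounds shown here alone, is how a phenyl ring, a primary amine or a carboxylic acid on this carbon would read in this test.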